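Replacing the Aryl Group on Compound 2

A few compounds are considered here, and "the series" means these few. Any claim that something is new, unique, unknown or untested is made for them only; others in the source may bear on it.

Of the compounds shown here, two with the same core have been measured in a functional assay on SiHa cells (Homo sapiens) for inhibition, read by CCK-8 assay, with a stated time of 72 h, tested at 1 uM (a lower number here means less inhibition of growth, a higher number more inhibition of growth at the concentration tested), so far. In that test, compound 1 (`CN(C)C(=O)c1cc2cnc(Nc3ccc(NC(=O)C4(C(=O)Nc5ccc(Br)cc5)CC4)cc3)nc2n1C1CCCC1`) gives 23.2% and compound 2 (`CN(C)C(=O)c1cc2cnc(Nc3ccc(NC(=O)C4(C(=O)Nc5ccc(Cl)c(C(F)(F)F)c5)CC4)cc3)nc2n1C1CCCC1`) gives -11.2% as the lower of the two numbers. The next structure is compound 3 (`CN(C)C(=O)c1cc2cnc(Nc3ccc(NC(=O)C4(C(=O)Nc5ccc(O)cc5)CC4)cc3)nc2n1C1CCCC1`), in which 4-hydroxyphenyl takes the place of 4-chloro-3-(trifluoromethyl)phenyl on an amide-type nitrogen (4-hydroxyphenyl in place of 4-chloro-3-(trifluoromethyl)phenyl on an amide-type nitrogen). Going by the values given here, only one measured step bears on this change, and it concerns the same place: putting 4-chloro-3-(trifluoromethyl)phenyl in place of 4-bromophenyl gave a number 34.4 percentage points lower from compound 1 to compound 2 (beyond the scatter) as a large change beyond the scatter. Compound 3 gives up the group found in the lower-scoring compound 2, and its 4-hydroxyphenyl looks more like the 4-bromophenyl of compound 1 (23.2%) in name and shape. Among the compounds with values here, no compound with 4-hydroxyphenyl has been measured, however, so a full return is not assumed. A partial recovery is expected, with an estimated a number 19.2 percentage points higher from compound 2 to compound 3 (beyond the scatter) in this assay as the likely move. The estimate for compound 3 is 8% with an expected range from -14% to 30% for repeat measurements.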

Compound 3, percent growth inhibition at one concentration: 69.5%
Beside the measured number, compound 3's estimate is 61.5 percentage points below it, outside the stated range (above it).
By their numbers in this assay, from the lowest: compound 2; then compound 1; then compound 3.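

In this assay, this position on the amide-type nitrogen proves far more responsive than the first two compounds could show: 4-hydroxyphenyl in place of 4-chloro-3-(trifluoromethyl)phenyl gives a number 80.7 percentage points higher from compound 2 to compound 3 (beyond the scatter) and turns a negative reading into clear growth inhibition. The earlier pair showed only a fall in the number at this position, whereas hydroxy in place of bromo on the aromatic carbon gives a number 46.3 percentage points higher from compound 1 to compound 3 (beyond the scatter) and shows that changing this aryl group can also lift the number well beyond that of compound 1. The information at hand offers no explanation for the size of either step.

From the compounds shown here alone, it remains open whether the rise belongs to the hydroxy group itself or would also appear with 4-methoxyphenyl, 4-aminophenyl or 4-carboxyphenyl on the same nitrogen. Going by these compounds, since all three compounds were read at a single concentration, it also remains open how the gaps between them would look across a range of concentrations.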